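This account rests on a few compounds, and the source may have more. Where it says the series, first, only, none or still open, it means among the compounds named here.

In a functional assay for agonist activity at 5-hydroxytryptamine receptor 4 (Cavia porcellus) (a higher number here means a larger maximal response, a lower number a smaller maximal response), compound 1 `C=CCn1c(=O)n(C(=O)NCCN2CCN(C)CC2)c2ccccc21` gives 0.63. Compound 2 `CCCCn1c(=O)n(C(=O)NCCN2CCN(C)CC2)c2ccccc21` gives < 0.3, a limit of the assay. Compound 3 `CCn1c(=O)n(C(=O)NCCN2CCN(C)CC2)c2ccccc21` gives < 0.3, again a limit of the assay.

Compound 3 therefore stands at the floor of what this assay reports, sharing it with compound 2 (the limit of < 0.3 in this assay, at which 2 of the 3 values shown sit). The measured steps a number at least 0.33 lower from compound 1 to compound 2 (beyond the scatter) and a number at least 0.33 lower from compound 1 to compound 3 (beyond the scatter) both concern the group on the aromatic nitrogen, and a step that the two limits leave unreadable from compound 2 to compound 3 leaves the size unreadable. Compound 4 `CCCCN1CCN(CCNC(=O)n2c(=O)n(CC)c3ccccc32)CC1` differs from compound 3 at another place: propyl in place of hydrogen on a saturated chain carbon bound to an amine nitrogen in a ring. Within the data shown here, no measured step touches this position, so no step bears on it directly, and nothing in the data shows a change here lifting a compound off the limit. Compound 4 is expected to remain near that limit, with a step that the limit leaves unreadable from compound 3 to compound 4 as the expected step. The estimate for compound 4 is 0.25, ranging from 0.1 to 0.45.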

Compound 4, intrinsic activity: the largest response reached, as a fraction of the reference agonist's: < 0.3
Compound 4: only a limit was reported (the forecaster's own chance of this, stated with the estimate: 60%); the middle value does not contradict the limit.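

Compound 3 and compound 4 both rest on a limit of this assay, so the step between them cannot be read. The compounds shown leave open whether propyl in place of hydrogen here would alter the response of a compound clear of that limit.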